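The source may report more compounds than this note shows. Statements on the series, on what has been measured and on what is new or still open speak of the compounds shown alone.

Compounds measured so far:
Compound 1, `c1cnc2c(c1)CCC[C@@H]2N(CC1CC1)C[C@H]1Cc2c(cccc2N2CCNCC2)CN1`: > 30000 nM
Compound 2, `Cc1cnc(CN(C)C[C@H]2Cc3c(cccc3N3CCNCC3)CN2)c(C)c1`: > 30000 nM
Compound 3, `CN(C[C@H]1Cc2c(cccc2N2CCN(Cc3ccccn3)CC2)CN1)[C@H]1CCCc2cccnc21`: > 30000 nM

All three values come from a functional assay on CCRF-CEM cells for agonist activity at C-X-C chemokine receptor type 4 (Homo sapiens), read by calcium flux, with a stated time of 25 min; on this read-out lower numbers stand for an effect already at smaller amounts and higher numbers for an effect only at larger amounts of compound. Compound 1 gives > 30000 nM in this assay, which is a limit of the assay and not a measured number. Compound 2 gives > 30000 nM, also a limit. Compound 3 gives > 30000 nM, again a limit. Compound 1 therefore stands at the limit of > 30000 nM in this assay, at which 3 of the 3 values shown sit, with nothing to set it apart from the other two.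

Compound 4, `CC(C)N(C[C@H]1Cc2c(cccc2N2CCNCC2)CN1)[C@H]1CCCc2cccnc21`, differs from compound 1 in one place: isopropyl in place of cyclopropylmethyl on an amine nitrogen. The cyclopropylmethyl leaves and an isopropyl enters on the amine nitrogen whose other neighbours are a saturated chain carbon and a saturated ring carbon. Among the compounds with values here, no step between two measured compounds is known here, so no measured comparison tells how a change at this nitrogen moves the read-out. The step of a number no higher from compound 1 to compound 4 (the limit leaves the size open) is expected to be essentially none beyond the scatter, in either direction. Compound 4 is expected to give about 30000 nM, with a range from 10000 nM to 100000 nM, and most likely the assay will again report only a limit.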

Compound 4, half-maximal effective concentration: > 30000 nM
Compound 4 was reported as a limit; the forecaster's own chance of this, stated with the estimate: 85%; the middle value sits exactly at the limit.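

Within the data shown here, replacing cyclopropylmethyl with isopropyl gives no step that can be read between compound 1 and compound 4, as each result is only a limit of the assay and not a measured number: the limit of > 30000 nM in this assay, at which 4 of the 4 values shown sit.

The compounds shown leave open how far each one lies past that limit, and whether a change at this amine nitrogen moves the read-out at all.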